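The source may report more compounds than this note shows. Statements on the series, on what has been measured and on what is new or still open speak of the compounds shown alone.

Working notes on the series.

Among the compounds with values here, the shared core carries a side chain on an aromatic oxygen, and the three measured members differ only there. Compound 1 `CC(C)=CCC/C(C)=C/CC1Cc2c(OCCCNC(=O)c3ccco3)cc(=O)n(CCCO)c2CC1(C)C` gives 2.8% in a functional assay on PANC-1 cells (Homo sapiens) for inhibition, read by MTT assay, with a stated time of 24 h, tested at 10 uM; on this read-out lower numbers stand for less inhibition and higher numbers for more inhibition at the one concentration tested (going by the name of the read-out). Compound 2 `CC(C)=CCC/C(C)=C/CC1Cc2c(OCCCNC(=O)c3cccs3)cc(=O)n(CCCO)c2CC1(C)C` gives 11.5% in the same read-out, the step being a number 8.7 percentage points higher from compound 1 to compound 2 (within the scatter). Compound 3 `COc1ccccc1NC(=O)Oc1cc(=O)n(CCCO)c2c1CC(C/C=C(\C)CCC=C(C)C)C(C)(C)C2` gives 0%. On these numbers compound 3 stands lowest of the three: one gap is a number 2.8 percentage points lower from compound 1 to compound 3 (within the scatter), while the other gap is a number 11.5 percentage points lower from compound 2 to compound 3 (beyond the scatter).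

Compound 4 `CC(C)=CCC/C(C)=C/CC1Cc2c(OC(=O)Nc3cccc(C(F)(F)F)c3)cc(=O)n(CCCO)c2CC1(C)C` is the next member. Against compound 3 the change is 3-(trifluoromethyl)phenyl in place of 2-methoxyphenyl on an amide-type nitrogen. Within the data shown here, no measured step touches this position: the steps from compound 1 to compound 3 and from compound 2 to compound 3 exchange the whole side chain on the aromatic oxygen, and the step from compound 1 to compound 2 swaps heteroaryl groups on a carbonyl carbon and stays within the scatter. None of them reads on an aryl swap on the amide-type nitrogen of compound 3. The three measured values all sit low in this assay, so the expected step is none beyond the scatter, a number 4 percentage points higher from compound 3 to compound 4 (within the scatter). Compound 4 is therefore estimated at 4%, within a range of 0% to 15%.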

Compound 4, a percentage reported as inhibition, at one concentration (the size of the read-out at that concentration, not a potency): 6.7%
Estimate against measurement, compound 4: 2.7 percentage points below, within the range that was stated.
By their numbers in this assay, from the lowest: compounds 3, 1, 4 and 2 (each within the scatter of the next, the first and the last beyond it).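

Within the data shown here, the aryl group on the amide-type nitrogen is read here for the first time: in this assay, 3-(trifluoromethyl)phenyl in place of 2-methoxyphenyl gives a number 6.7 percentage points higher from compound 3 to compound 4 (within the scatter), so this swap is not told apart from repeat scatter. Earlier steps exchanged the whole side chain on the aromatic oxygen or swapped heteroaryl groups on a carbonyl carbon, whereas this pair keeps the carbamoyl link and changes only the aryl group beyond the amide-type nitrogen. On this single pair, the read-out does not separate the two aryl groups, and no measurement bearing on why that should be so accompanies the result.

Still open, as far as these compounds go, is whether an aryl group carrying a carboxylic acid or an amine on the amide-type nitrogen, or a longer alkyl chain there in place of the aryl group, would give a step beyond the scatter from compound 3. Also open, from the compounds shown here alone, is how compound 3 and compound 4 would read at concentrations other than the single one used in this assay, since one concentration gives no potency for either.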